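Dimethylamino for methoxy on the shared core

A few compounds are considered here, and "the series" means these few. Any claim that something is new, unique, unknown or untested is made for them only; others in the source may bear on it.

Working notes on three compounds and their cytotoxicity in a functional assay on CCRF-CEM cells (Homo sapiens) for cytotoxicity, with a stated time of 72 h; on this read-out higher numbers stand for weaker inhibition and lower numbers for stronger inhibition. Compound 1 `COc1ccc(/C=C2\CCC/C(=C\c3ccc([N+](=O)[O-])cc3)C2=O)cc1` gives 250000 nM in this assay, the highest number of the three and, with both gaps beyond the scatter, the weakest inhibitor of this set. Compound 2 `Cc1ccc(/C=C2\CCC/C(=C\c3cccc([N+](=O)[O-])c3)C2=O)cc1` gives 10100 nM, and compound 3 `O=C1CCCC/C1=C\c1ccccc1[N+](=O)[O-]` gives 36400 nM. Among the compounds with values here, no pair of measured compounds differs in only one place, so no single-point step is available to calibrate any change.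

Compound 4 `CN(C)c1ccc(/C=C2\CCC/C(=C\c3ccc([N+](=O)[O-])cc3)C2=O)cc1` is the analogue of compound 1 with dimethylamino in place of methoxy on an aromatic carbon. Within the data shown here, no measured compound carries a dimethylamino group, so nothing among the measured values speaks directly to this change; the only anchor is compound 1 at the weak end of the set. The expected step of a 3.1-fold lower number from compound 1 to compound 4 (0.49 log units; beyond the scatter) is a modest lowering of the number, held within a wide range to reflect the absence of any comparable measured step. For compound 4 the estimate in this assay is 80000 nM, with a range from 15000 nM to 400000 nM.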

Compound 4, half-maximal inhibitory concentration: > 500000 nM
Compound 4 was reported as a limit; the forecaster's own chance of this, stated with the estimate: 15%; at least 6.2-fold (0.79 log units) between middle value and limit.
By their numbers in this assay, from the lowest: compound 2; then compound 3; then compound 1. At a limit, above all of these: compound 4.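

In this assay, within the data shown here, dimethylamino in place of methoxy on an aromatic carbon, para to a large group, gives the first single-place step: an at least 2.0-fold higher number from compound 1 to compound 4 (0.30 log units; that floor lies within the scatter). Compound 4 is reported as a limit, > 500000 nM, not as a number. This exchange therefore brings no lowering of the number at this position, and how far the step runs cannot be read past the top of the range: the limit of > 500000 nM in this assay, at which 1 of the 4 values shown sits.

Still open, going by these compounds, is whether another group in the same place, such as a hydroxyl, a primary amine or a carboxylic acid, would bring the number below that of compound 1 at 250000 nM. Also open, on these data alone, is whether the exchange of methoxy for dimethylamino would read the same on any other core.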